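Swapping the Amide Substituent: From Compound 2 to Compound 3

The compounds below may be only part of what the source reports. "The series", "measured", "known", "first", "only" and "open" are said of these compounds alone.

Compound 1 `CC1CCCN(C(=O)CN2CN(c3ccccc3)C3(CCN(C(=O)c4ccc(C5CCCCC5)cc4)CC3)C2=O)C1` gives 3600 nM in an assay on HEK293 cells for displacement of a labelled ligand from NPC1-like intracellular cholesterol transporter 1 (Homo sapiens); on this read-out lower numbers stand for stronger inhibition and higher numbers for weaker inhibition.
Compound 2 `O=C(CN1CN(c2ccccc2)C2(CCN(C(=O)c3ccc(C4CCCCC4)cc3)CC2)C1=O)NCCO` gives 2000 nM in this assay.

Compound 2 carries the lower of these two numbers, yet the step of a 1.8-fold lower number from compound 1 to compound 2 (0.26 log units; within the scatter) lies within the scatter, so the two cannot be separated. Compound 3 `NC(=O)C1CCCN(C(=O)CN2CN(c3ccccc3)C3(CCN(C(=O)c4ccc(C5CCCCC5)cc4)CC3)C2=O)C1` carries 3-carbamoylpiperidin-1-yl in place of (2-hydroxyethyl)amino on a carbonyl carbon. Going by the values given here, the only measured step at this carbonyl carbon, a 1.8-fold lower number from compound 1 to compound 2 (0.26 log units; within the scatter), exchanged a 3-methylpiperidin-1-yl group for the (2-hydroxyethyl)amino group without moving beyond the scatter, so reinstalling a piperidin-1-yl group is expected to change little: an estimated 1.4-fold higher number from compound 2 to compound 3 (0.15 log units; within the scatter). Compound 3 is therefore expected to give 2800 nM, between 1200 nM and 6500 nM.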

Compound 3, half-maximal inhibitory concentration: 3100 nM
Compound 3: the middle estimate sits 1.1-fold (0.04 log units) below what was measured; the measured number falls inside the stated range.
By their numbers in this assay, from the lowest: compounds 2, 3 and 1 (each within the scatter of the next).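

At this carbonyl carbon, the larger, ring-bearing 3-carbamoylpiperidin-1-yl group can stand in for the open-chain (2-hydroxyethyl)amino group without a separable effect in this assay (a 1.6-fold higher number from compound 2 to compound 3 (0.19 log units; within the scatter)). On the saturated ring carbon, carbamoyl and methyl cannot be told apart either (a 1.2-fold lower number from compound 1 to compound 3 (0.06 log units; within the scatter)). Nothing available explains this insensitivity. As far as these compounds go, whether any group at these places can move the number beyond the scatter remains open. A carboxylic acid or an amine on that ring carbon would be one way to probe this.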